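Adding a 4-nitrophenyl group to a nitric oxide inhibitor

The compounds below may be only part of what the source reports. "The series", "measured", "known", "first", "only" and "open" are said of these compounds alone.

Compound 1 `CC1COC2(C=CC(=O)C=C2)N(c2ccccc2)C1=O` is the parent of this small set. In a functional assay on BV-2 cells (Mus musculus), read by Griess assay, with a stated time of 24 h (on this read-out higher numbers stand for weaker inhibition and lower numbers for stronger inhibition), compound 1 gives 1220 nM, the highest number of the three measured compounds and hence the weakest inhibition among them. Two measured changes at the same place show what adding a group there does. Compound 2 `C=C(C)CC1COC2(C=CC(=O)C=C2)N(c2ccccc2)C1=O` gives 450 nM, a step of a 2.7-fold lower number from compound 1 to compound 2 (0.43 log units; beyond the scatter). Compound 3 `O=C1C=CC2(C=C1)OCC(Cc1ccc(F)cc1)C(=O)N2c1ccccc1` gives 400 nM, a step of a 3.1-fold lower number from compound 1 to compound 3 (0.48 log units; beyond the scatter). Between them, a 1.1-fold lower number from compound 2 to compound 3 (0.05 log units; within the scatter) means the two added groups are indistinguishable here.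

Compound 4 `O=C1C=CC2(C=C1)OCC(Cc1ccc([N+](=O)[O-])cc1)C(=O)N2c1ccccc1` is not yet measured. It differs from compound 1 by 4-nitrophenyl in place of hydrogen on a saturated chain carbon bound to a saturated ring carbon. Both known steps from compound 1 at this position went toward stronger inhibition by a modest amount, and the new group is again an aromatic ring attached at the same place, most like the change toward compound 3. The expected step is therefore a 2.9-fold lower number from compound 1 to compound 4 (0.46 log units; beyond the scatter), a modest gain in the same direction, because the change toward compound 3 gave a 3.1-fold lower number from compound 1 to compound 3 (0.48 log units; beyond the scatter). For compound 4 the estimate in this assay is 420 nM, with a likely range from 200 nM to 900 nM.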

Compound 4, half-maximal inhibitory concentration: 430 nM
For compound 4 the middle estimate is 1.0-fold (0.01 log units) below the measured one; the range from low to high includes it.
By their numbers in this assay, from the lowest: compounds 3, 4 and 2 (each within the scatter of the next); then compound 1.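

The nitro and fluoro versions of the aromatic ring cannot be told apart in this assay, with a 1.1-fold higher number from compound 3 to compound 4 (0.03 log units; within the scatter), so swapping one for the other on the aromatic carbon gives no readable difference. The 4-nitrophenyl group likewise cannot be separated from the 1-methylethenyl group, with a 1.0-fold lower number from compound 2 to compound 4 (0.02 log units; within the scatter), and the step from the parent, a 2.8-fold lower number from compound 1 to compound 4 (0.45 log units; beyond the scatter), makes three different added groups that all give a modest gain beyond the scatter, with none standing out from the others. Nothing available explains why these groups give such similar numbers.

Still open, going by these compounds, is whether an amine or a carboxylic acid in place of the nitro would keep the number at this level or shift it. The same question applies to a longer chain in place of the 4-nitrophenyl group.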